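The compounds below may be only part of what the source reports. "The series", "measured", "known", "first", "only" and "open" are said of these compounds alone.

Compound 1 `C=CC[C@H]1C[C@]2([C@@H](C)Cc3ccc(OC)c(C)c3)OCOC2=CC1=O`: 410 nM
Compound 2 `C=CC[C@H]1C[C@]2([C@@H](C)Cc3ccc(OC)c(Cl)c3)OCOC2=CC1=O`: 240 nM

In a functional assay on M14 cells (Homo sapiens) for antiproliferative activity, with a stated time of 72 h (a higher number here means a weaker inhibitor, a lower number a stronger inhibitor), compound 2 gives 240 nM, and its only measured companion, compound 1, sits within the usual scatter of it, as a 1.7-fold lower number from compound 1 to compound 2 (0.23 log units; within the scatter) shows. Compound 3 `C=CC[C@H]1C[C@]2([C@@H](C)Cc3ccc(OC)c(F)c3)OCOC2=CC1=O` differs from compound 2 by fluoro in place of chloro on an aromatic carbon. Within the data shown here, the single step in hand, a 1.7-fold lower number from compound 1 to compound 2 (0.23 log units; within the scatter), concerned a group at this same aromatic carbon and stayed within the scatter, so a step of similar modest size is expected here, a 1.5-fold higher number from compound 2 to compound 3 (0.16 log units; within the scatter). Compound 3 is therefore estimated at 350 nM, in a range from 150 nM to 900 nM.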

Compound 3, half-maximal inhibitory concentration: 8 nM
Estimate against measurement, compound 3: 44-fold (1.64 log units) above; the measured number lies below the stated range.
By their numbers in this assay, from the lowest: compound 3; then compounds 2 and 1 (each within the scatter of the next).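

This aromatic carbon, ortho to a methoxy group, proves far more sensitive than the earlier pair suggested. In this assay there is a 30-fold lower number from compound 2 to compound 3 (1.48 log units; beyond the scatter) and also a 51-fold lower number from compound 1 to compound 3 (1.71 log units; beyond the scatter), both beyond the scatter, although methyl and chloro themselves stayed within it. One heavy atom exchanged for another, with no hydrogen-bond donor, acceptor or net charge involved, is enough to separate fluoro from both, and no measurement here explains why.

Going by these compounds, whether this holds only for fluoro remains open, since hydrogen, hydroxyl or nitrile at this carbon would test that. On these data alone, it is also open whether the effect survives when the methoxy group is replaced by ethoxy.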